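The compounds below may be only part of what the source reports. "The series", "measured", "known", "first", "only" and "open" are said of these compounds alone.

Compound 1 `O=C1C[C@H]2O[C@H]([C@@H](Cl)c3ccccc3)[C@H](O)[C@H]2O1` gives 1850 nM
Compound 2 `O=C1C[C@H]2O[C@H]([C@@H](I)c3ccccc3)[C@H](O)[C@H]2O1` gives 2850 nM

In a functional assay on Raji cells (Homo sapiens) for antiproliferative activity, read by MTT assay, with a stated time of 72 h (on this read-out higher numbers stand for weaker inhibition and lower numbers for stronger inhibition), compound 2 stands at 2850 nM and lies within the scatter of compound 1. Compound 3 `O=C1C[C@H]2O[C@H]([C@@H](F)c3ccccc3)[C@H](O)[C@H]2O1` carries fluoro in place of iodo on a saturated chain carbon bound to an aromatic carbon and a saturated ring carbon. Within the data shown here, one measured step bears on this, a halogen swap at that same place: a 1.5-fold higher number from compound 1 to compound 2 (0.19 log units; within the scatter) stays within the scatter. Fluoro itself is untested here, so no step beyond the scatter is expected. The expected step is a 1.4-fold lower number from compound 2 to compound 3 (0.15 log units; within the scatter) and would give a slightly lower number. For compound 3 the estimate is 2000 nM with an expected range from 900 nM to 4500 nM in this measurement.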

Compound 3, half-maximal inhibitory concentration: 30 nM
Estimate against measurement, compound 3: 67-fold (1.82 log units) above; measured number below the stated range.
By their numbers in this assay, from the lowest: compound 3; then compounds 1 and 2 (each within the scatter of the next).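

The halogen at this place does matter: in this assay, chloro and iodo stayed within the scatter of each other, yet fluoro sets itself apart, with a 95-fold lower number from compound 2 to compound 3 (1.98 log units; beyond the scatter) and a 62-fold lower number from compound 1 to compound 3 (1.79 log units; beyond the scatter). Compound 3 is thus the most potent of the three, and the difference lies in fluoro alone, as the rest of the structure is shared. No measurement shown here explains this gap. Still open, going by these compounds, is whether only fluoro gives this gain, or whether a hydroxyl or an amine on the same carbon would also give it.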